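Methyl to Trifluoromethyl on a Benzimidazole Amine

The source may report more compounds than this note shows. Statements on the series, on what has been measured and on what is new or still open speak of the compounds shown alone.

Measured compounds:
compound 1, `NCc1cccc(Cn2c(N)nc3ccccc32)c1`, "not active" (no number reported) in an assay on HEK293 cells for agonist activity at Toll-like receptor 8 (Homo sapiens), read by reporter gene assay; a higher number here means that more compound is needed for the effect, a lower number that less compound is needed
compound 2, `CCCCCn1c(N)nc2c(C)cccc21`, 1130 nM
compound 3, `CCCCCn1c(N)nc2ccc(C)cc21`, 7210 nM

Compound 1 gave no measurable activity and no number. Of the two compounds with a number, compound 2 has the lower value; compound 3 stands higher by a gap that lies beyond the scatter. Compound 4, `CCCCCn1c(N)nc2c(C(F)(F)F)cccc21`, differs from compound 2 by trifluoromethyl in place of methyl on an aromatic carbon. Among the measured compounds shown here, no measured pair shows this exchange, so the direction of the step rests on expectation alone. The expected step from compound 2 to compound 4 is a 1.3-fold higher number from compound 2 to compound 4 (0.12 log units; within the scatter), within the scatter in either direction. Compound 4 is therefore estimated at 1500 nM, with a range from 400 nM to 6000 nM.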

Compound 4, half-maximal effective concentration: "not active" (no number reported)
The entry for compound 4 holds no number; there is nothing to compare the estimate with.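

Among the compounds shown here, compound 4 carries no number, so no step from compound 2 to compound 4 can be read. The compounds shown leave open how trifluoromethyl in place of methyl changes the value. No other measurement shown bears on this result.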